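Methoxy Added to the Aryl Sulfone of Compound 2

A few compounds are considered here, and "the series" means these few. Any claim that something is new, unique, unknown or untested is made for them only; others in the source may bear on it.

Among the measured compounds shown here, compound 2 `O=S(=O)(c1ccccc1)c1nc2ccccc2nc1N1CCC(O)CC1` is the only member of the series with a number in a functional assay on A549 cells (Homo sapiens) for cytotoxicity, read by MTT assay, with a stated time of 72 h; a lower number here means a stronger inhibitor, a higher number a weaker inhibitor. In this assay, for the measured compounds named here, compound 2 gives 2060 nM, the single numeric value shown. Compound 1 `COc1ccc(S(=O)(=O)c2nc3ccccc3nc2N2CCCC2)cc1` differs from compound 2 in two places. In this assay compound 1 gives > 50000 nM, which is a limit of the assay and not a number. One of the two values shown sits at that limit (the limit of > 50000 nM in this assay, at which 1 of the 2 values shown sits). Going by the values given here, no pair of measured compounds differing in one place exists, so the size of the step from compound 2 to compound 3 cannot be read from a measured pair.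

Compound 3 `COc1ccc(S(=O)(=O)c2nc3ccccc3nc2N2CCC(O)CC2)cc1` has not yet been measured. It differs from compound 2 by methoxy in place of hydrogen on an aromatic carbon; the group sits on an aromatic carbon of a six-membered aromatic ring of carbon only, para to a large group. Compound 1, which also bears a methoxy, sits at the limit, but it carries a different ring on the other side, so its value cannot be assigned to the methoxy alone. The step of a 3.9-fold higher number from compound 2 to compound 3 (0.59 log units; beyond the scatter) is expected to weaken inhibition beyond the usual scatter, with wide uncertainty. Compound 3 is expected at 8000 nM, in the range 2000 nM to 50000 nM, with a fair chance that only a limit is reported.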

Compound 3, half-maximal inhibitory concentration: 5110 nM
Estimate against measurement, compound 3: 1.6-fold (0.19 log units) above; measured number inside the range.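

In this assay, the phenyl to 4-methoxyphenyl change can now be read directly with the 4-hydroxypiperidin-1-yl group held constant: methoxy in place of hydrogen on the aromatic carbon gives a 2.5-fold higher number from compound 2 to compound 3 (0.39 log units; beyond the scatter), so this position accepts methoxy at a modest cost and compound 3 still has a numeric value. With the 4-methoxyphenyl sulfone held constant, 4-hydroxypiperidin-1-yl in place of pyrrolidin-1-yl gives an at least 9.7-fold lower number from compound 1 to compound 3 (0.99 log units; beyond the scatter), which shows that the result for compound 1 cannot be assigned to the methoxy alone. That second step is a bound and not an exact size, since the value of compound 1 is a limit: the limit of > 50000 nM in this assay, at which 1 of the 3 values shown sits.

As far as these compounds go, it remains open whether the modest loss is specific to methoxy or would also appear with fluorine, a hydroxy group or a dimethylamino group on the same aromatic carbon. From the compounds shown here alone, it also remains open whether the hydroxy group of the 4-hydroxypiperidin-1-yl ring is what matters, a question that an unsubstituted piperidine or a 4-aminopiperidine on the shared core would address.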